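The compounds below may be only part of what the source reports. "The series", "measured", "known", "first", "only" and "open" are said of these compounds alone.

Measured so far:
Compound 1 `CC(C)=CC[C@@H](OC[C@@H](C)O)C1=CC(=O)c2c(O)ccc(O)c2C1=O` gives 14300 nM in a functional assay on DU-145 cells (Homo sapiens) for cytotoxicity, read by MTT assay; on this read-out higher numbers stand for weaker inhibition and lower numbers for stronger inhibition.
Compound 2 `COC(C)CO[C@H](CC=C(C)C)C1=CC(=O)c2c(O)ccc(O)c2C1=O` gives 16600 nM.
Compound 3 `CC(C)=CC[C@@H](OC(=O)C1CCCO1)C1=CC(=O)c2c(O)ccc(O)c2C1=O` gives 10500 nM.

On these three numbers compound 3 has the lowest value, but its separation from the other two is small: the step of a 1.4-fold lower number from compound 1 to compound 3 (0.13 log units; within the scatter) and the step of a 1.6-fold lower number from compound 2 to compound 3 (0.20 log units; within the scatter) both stay within the scatter, so compound 3 cannot be singled out as the most active of the set. All three compounds share the same core and differ only in the group attached to the oxygen on a saturated carbon.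

Compound 4 `CCC(CO[C@H](CC=C(C)C)C1=CC(=O)c2c(O)ccc(O)c2C1=O)OC(C)=O` carries a different group at that same position. The change from compound 3 is 2-acetoxybutyl in place of (oxolan-2-yl)carbonyl on an oxygen on a saturated carbon.

The earlier steps shown here that bear on this position are a 1.4-fold lower number from compound 1 to compound 3 (0.13 log units; within the scatter), a 1.6-fold lower number from compound 2 to compound 3 (0.20 log units; within the scatter) and a 1.2-fold higher number from compound 1 to compound 2 (0.06 log units; within the scatter); each swapped one group at this oxygen for another, and each stayed within the scatter. Nothing in the measured set suggests that changing this group moves the read-out of this assay beyond the scatter, and the same is expected here: the step of a 1.2-fold higher number from compound 3 to compound 4 (0.08 log units; within the scatter) is expected to be small. Compound 4 is therefore estimated at 12500 nM, with a range from 6000 nM to 26000 nM.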

Compound 4, half-maximal inhibitory concentration: 25400 nM
For compound 4 the middle estimate is 2.0-fold (0.31 log units) below the measured one; the range from low to high includes it.
By their numbers in this assay, from the lowest: compounds 3, 1, 2 and 4 (each within the scatter of the next, the first and the last beyond it).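

In this assay, this position now shows its first step beyond the scatter, a 2.4-fold higher number from compound 3 to compound 4 (0.38 log units; beyond the scatter), with 2-acetoxybutyl in place of (oxolan-2-yl)carbonyl on an oxygen on a saturated carbon, so the choice of group here can shift the read-out, if only modestly. The separation holds for this one pair alone: the steps of a 1.5-fold higher number from compound 2 to compound 4 (0.18 log units; within the scatter) and a 1.8-fold higher number from compound 1 to compound 4 (0.25 log units; within the scatter) both stay within the scatter, so 1-acetoxypropyl cannot be told apart from 1-methoxyethyl or 1-hydroxyethyl at this place. No measurement shown accounts for the difference between compound 3 and compound 4.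

The group in compound 3 carries a five-membered ring and the group in compound 4 carries an acetoxy unit on an open chain, and these two features change together, so the compounds shown do not say which of them goes with the step. Going by these compounds, how an amine, a carboxylic acid or a plain hexyl chain on this oxygen would read out also stays open.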